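This account rests on a few compounds, and the source may have more. Where it says the series, first, only, none or still open, it means among the compounds named here.

Measured in an ADME assay on CHO cells (Cricetulus griseus) for cytotoxicity, read by MTT assay; a higher number here means a weaker inhibitor, a lower number a stronger inhibitor:
- compound 1 `C=CCN1CCC(CNc2ccnc3cc(Cl)ccc23)C(C)(C)C1`: 29900 nM
- compound 2 `C=CCN1C[C@@H](OCc2ccccc2)[C@@H](CNCc2ccc3ccccc3n2)C(C)(C)C1`: 211000 nM
- compound 3 `C=CCN1C[C@@H](OCc2ccccc2)[C@@H](CNc2ccnc3cc(Cl)ccc23)C(C)(C)C1`: 122000 nM

Compound 2, at 211000 nM, lies within the scatter of compound 3, at 122000 nM. Compound 1 gives 29900 nM. The numbers of compound 2 and compound 3 both stand beyond the scatter from that of compound 1, on the higher side of it, so compound 2 sits at the weak end of this small set.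

The next compound to be tested is compound 4 `C=CCN1C[C@@H](OCc2ccccc2)[C@@H](CNCc2cc3ccccc3nc2Cl)C(C)(C)C1`. It differs from compound 2 by one change: 2-chloroquinolin-3-yl in place of quinolin-2-yl on a saturated chain carbon bound to an amine nitrogen. In words, 2-chloroquinolin-3-yl stands in place of quinolin-2-yl on a saturated chain carbon bound to an amine nitrogen.

Among the compounds with values here, no measured pair isolates this change, so any expectation rests on indirect evidence. Compound 3 shares much of its structure with compound 2 but carries a different group on the amine, and compound 3 gives 122000 nM, which is within the scatter of compound 2. That single comparison suggests that the group on the amine may not move the number far. The estimated change is a 1.4-fold lower number from compound 2 to compound 4 (0.15 log units; within the scatter), which would be a small drift toward a lower number and no step beyond the scatter. For compound 4 the expected value is 150000 nM, with an estimated range from 65000 nM to 320000 nM.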

Compound 4, half-maximal inhibitory concentration: 199000 nM
Beside the measured number, compound 4's estimate is 1.3-fold (0.12 log units) below it, and the stated range covers the measured number.
By their numbers in this assay, from the lowest: compound 1; then compounds 3, 4 and 2 (each within the scatter of the next).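

In this assay, the swap of quinolin-2-yl for 2-chloroquinolin-3-yl on a saturated chain carbon bound to an amine nitrogen gives a 1.1-fold lower number from compound 2 to compound 4 (0.03 log units; within the scatter), so the two numbers cannot be told apart. Among the earlier compounds, no pair differed at this place alone, so this is the first direct reading of a change there, and it shows that this particular exchange of one quinoline group for another, which adds a chlorine, gives no step beyond the scatter. Nothing among the available measurements offers an explanation for this outcome.

The change alters the chlorine and the point of attachment together, so the compounds shown leave open what each does alone, and a plain quinolin-3-yl group on the same chain carbon would part the two. Also open, going by these compounds, is whether a group of a different kind at this place, such as a 2-aminoquinolin-3-yl group or a carboxylic acid on the quinoline, would give a number beyond the scatter of compound 2.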